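Nitrofuran substitution on the dimethoxybenzyl series

The compounds below may be only part of what the source reports. "The series", "measured", "known", "first", "only" and "open" are said of these compounds alone.

The series is followed in a functional assay on the whole organism (strain Wistar Albino) for inhibition, with Rattus norvegicus as the target, read by paw edema, with a stated time of 4 h, at a dose of 20 mg/kg; on this read-out lower numbers stand for less inhibition and higher numbers for more inhibition at the one dose given (going by the name of the read-out). Compound 1 `COc1ccc(Cc2nnc3sc(-c4ccnc(F)c4)nn23)cc1OC` gives 21.5% in this assay. Compound 2 `COc1ccc(Cl)c(-c2nnc3n2NC(c2ccco2)S3)c1` gives 25.6% in this assay. Compound 3 `COc1ccc(Cc2nnc3n2NC(c2ccco2)S3)cc1OC` gives 24.6% in this assay, which is the second highest of the three numbers; its nearest neighbour is compound 2, and the gap between the two values lies within the usual scatter, as does the gap to compound 1, so the three values cannot be told apart.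

The next compound, compound 4 `COc1ccc(Cc2nnc3n2NC(c2ccc([N+](=O)[O-])o2)S3)cc1OC`, is not yet measured in this assay. It differs from compound 3 by nitro in place of hydrogen on an aromatic carbon. Among the compounds with values here, no step between two measured compounds is available to show what such a change does here, and the three measured values themselves spread no wider than the scatter.

On that basis the step from compound 3 to compound 4 is expected to be small, with no reliable direction, and most likely to stay within the scatter. For compound 4 the estimated result in this assay is 27%, with a range from 15% to 40%. The estimated step is a number 2.4 percentage points higher from compound 3 to compound 4 (within the scatter) and is expected to remain within the scatter.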

Compound 4, a percentage reported as inhibition, in the whole organism at one dose (the size of the read-out at that dose, not a potency): 23.7%
Compound 4: middle estimate off by 3.3 percentage points, on the high side, within the range that was stated.
By their numbers in this assay, from the lowest: compounds 1, 4, 3 and 2 (each within the scatter of the next).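

In this assay, within the data shown here, the step of a number 0.9 percentage points lower from compound 3 to compound 4 (within the scatter) is the first that can be read between two measured compounds, and it shows that going from furan-2-yl to 5-nitrofuran-2-yl on the dimethoxybenzyl compound gives no change that can be told from the scatter. The aromatic carbon next to the ring oxygen of the five-membered aromatic ring therefore accepts a nitro in this whole-animal read-out without a visible gain or loss at the one dose and the one time given, although a single step at a single dose says nothing of potency. No measurement on the compounds shown bears on why the value stays where it does.

Still open, from the compounds shown here alone, is whether any other group at this same place, such as an amine, a carboxylic acid or a longer chain, would give a step beyond the scatter. Also open, going by these compounds, is whether the same nitro change on compound 2, with its different aryl group, would give a step of like size.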